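The source may report more compounds than this note shows. Statements on the series, on what has been measured and on what is new or still open speak of the compounds shown alone.

Three related chalcones have been tested in a functional assay on CNE-2 cells (Homo sapiens) for antiproliferative activity, read by sulforhodamine B assay, with a stated time of 48 h; a higher number here means a weaker inhibitor, a lower number a stronger inhibitor. Compound 1 `COc1ccc(/C=C/C(=O)c2ccccc2-c2cccc(F)c2)cc1OC` gives 650 nM in this assay. Compound 2 `COc1ccc(/C=C/C(=O)c2ccccc2-c2cccc(F)c2)cc1O` gives 17 nM. The change from compound 1 to compound 2 is hydrogen in place of methyl on an oxygen on an aromatic ring, and it brought a 38-fold lower number from compound 1 to compound 2 (1.58 log units; beyond the scatter). Compound 3 `COc1ccc(C(=O)/C=C/c2ccccc2-c2ccc(F)cc2)cc1OC` gives 7600 nM, the highest number of the three; the difference between the core of compound 3 and the core of compound 1 is not broken down here.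

Compound 4 `COc1cc(C(=O)/C=C/c2ccccc2-c2ccc(F)cc2)ccc1O` has not yet been measured. It differs from compound 3 by hydrogen in place of methyl on an oxygen on an aromatic ring, the same change that separates compound 1 from compound 2, made at a place described in the same words. Within the data shown here, because the step of a 38-fold lower number from compound 1 to compound 2 (1.58 log units; beyond the scatter) was large, a drop is expected for compound 4 as well, though the two cores differ and only one earlier example of this change is known, so a more modest step of about a 10-fold lower number from compound 3 to compound 4 (1.00 log units; beyond the scatter) is expected. On that basis compound 4 is estimated at 760 nM, with a likely range from 200 nM to 3000 nM.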

Compound 4, half-maximal inhibitory concentration: 4800 nM
Estimate against measurement, compound 4: 6.3-fold (0.80 log units) below; measured number above the stated range.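

In this assay, replacing methoxy with hydroxy on the core of compound 3 gives a 1.6-fold lower number from compound 3 to compound 4 (0.20 log units; within the scatter), so compound 3 and compound 4 cannot be told apart in this assay. The change therefore does not carry over from one core to the other with the same size, and the large step seen on the core of compound 1 cannot be assumed for a new core in this series: the same change on two cores in this assay, a 38-fold lower number (1.58 log units; beyond the scatter) from compound 1 to compound 2 and a 1.6-fold lower number (0.20 log units; within the scatter) from compound 3 to compound 4, 24-fold (1.38 log units) apart, beyond the scatter of two such steps. Among these compounds, this shows that the effect of the change depends on its surroundings, but it rests on only two pairs and does not show which of the several differences between the two cores is responsible.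

The compounds shown leave open which of those differences between the cores matters, since no pair here separates them. They also leave open what an amine or a carboxylic acid in place of the hydroxy, or a longer chain such as ethoxy in place of the methoxy, would do on either core.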